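The source may report more compounds than this note shows. Statements on the series, on what has been measured and on what is new or still open speak of the compounds shown alone.

In a functional assay on K562 cells (Homo sapiens) for cytotoxicity, read by sulforhodamine B assay, with a stated time of 48 h (on this read-out lower numbers stand for stronger inhibition and higher numbers for weaker inhibition), compound 1 (`CC1(C)CNC(=O)c2cc(-c3ccc([N+](=O)[O-])cc3)n(-c3ccc(Cl)cc3)c2C1`) gives 15100 nM, a measured number. Compound 2 (`CC1(C)CNC(=O)c2cc3n(c2C1)CCc1cc(Cl)ccc1-3`) gives only a limit, > 100000 nM, so it has no exact position on this scale. That leaves (the limit of > 100000 nM in this assay, at which 1 of the 2 values shown sits). The two values show compound 2 reported past the limit, while compound 1 has a number well short of it.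

Compound 3 (`COc1ccc2c(c1)CCn1c-2cc2c1CC(C)(C)CNC2=O`) has methoxy in place of chloro on an aromatic carbon, a change at a position meta to a fused ring and para to a fused ring: methoxy in place of chloro on an aromatic carbon. Going by the values given here, no measured step between compounds that differ in one place is available to size this change in this assay. The expectation is therefore for no change beyond the scatter, with compound 3 remaining weak and quite possibly reported as a limit again. This expectation rests on the limit for compound 2, > 100000 nM. The expected change is an at least 1.1-fold lower number from compound 2 to compound 3 (0.04 log units; that floor lies within the scatter). Compound 3 is estimated at 90000 nM, with an expected range from 25000 nM to 200000 nM.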

Compound 3, half-maximal inhibitory concentration: > 100000 nM
Compound 3: a limit, no number; the forecaster's own chance of this, stated with the estimate: 60%; at least 1.1-fold (0.04 log units) between middle value and limit.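

Compound 2 and compound 3 both give only a limit in this assay, so no step can be read for methoxy in place of chloro: the limit of > 100000 nM in this assay, at which 2 of the 3 values shown sit.

The compounds shown leave open how methoxy and chloro compare at this place on the shared core, as neither compound has a number on this scale.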